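This account rests on a few compounds, and the source may have more. Where it says the series, first, only, none or still open, it means among the compounds named here.

Three compounds share one core and differ only in a single group on one aromatic ring. Compound 1 `NCc1ccc(CN(Cc2nc3ccccc3[nH]2)C2CCCc3cccnc32)c(CN)c1` carries an aminomethyl group there; in a functional assay on CEM-CCRF cells for antagonist activity at C-X-C chemokine receptor type 4 (Homo sapiens), read by calcium flux (on this read-out higher numbers stand for weaker inhibition and lower numbers for stronger inhibition), compound 1 gives 10 nM. Compound 2 `NCc1cc(CO)ccc1CN(Cc1nc2ccccc2[nH]1)C1CCCc2cccnc21` carries a hydroxymethyl group instead, and in this assay compound 2 gives 11 nM. Compound 3 `NCc1cc(C(N)=O)ccc1CN(Cc1nc2ccccc2[nH]1)C1CCCc2cccnc21` carries a carbamoyl group, and in this assay compound 3 gives 15 nM, the highest of the three numbers, though the steps to its neighbours, a 1.4-fold higher number from compound 2 to compound 3 (0.13 log units; within the scatter) and a 1.5-fold higher number from compound 1 to compound 3 (0.18 log units; within the scatter), both lie within the scatter, so no order among the three can be read from them.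

Compound 4 `CO/N=C/c1ccc(CN(Cc2nc3ccccc3[nH]2)C2CCCc3cccnc32)c(CN)c1` takes the same position one step further: a group of 4 heavy atoms (2 carbon, 1 nitrogen, 1 oxygen; no ring) in place of a group of 3 heavy atoms (1 carbon, 1 nitrogen, 1 oxygen; no ring), on an aromatic carbon, on an aromatic carbon of a six-membered aromatic ring of carbon only, para to a large group. The measured steps that bear on this position, a 1.1-fold higher number from compound 1 to compound 2 (0.04 log units; within the scatter), a 1.5-fold higher number from compound 1 to compound 3 (0.18 log units; within the scatter) and a 1.4-fold higher number from compound 2 to compound 3 (0.13 log units; within the scatter), were all within the scatter, so the expected step of a 1.2-fold higher number from compound 3 to compound 4 (0.08 log units; within the scatter) in this assay is also no larger than the scatter. Compound 4 is therefore estimated at 18 nM, within a range from 8 nM to 45 nM.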

Compound 4, half-maximal inhibitory concentration: 5 nM
Compound 4: the middle estimate sits 3.6-fold (0.56 log units) above what was measured; the measured number lies below the stated range.
By their numbers in this assay, from the lowest: compounds 4, 1, 2 and 3 (each within the scatter of the next, the first and the last beyond it).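

Until now, no group at this position had moved the number beyond the scatter in this assay. The group of 4 heavy atoms, with 0 hydrogen-bond donors, changes that, giving a 3.0-fold lower number from compound 3 to compound 4 (0.48 log units; beyond the scatter) and a 2.2-fold lower number from compound 2 to compound 4 (0.34 log units; beyond the scatter), both modest, although a 2.0-fold lower number from compound 1 to compound 4 (0.30 log units; within the scatter) remains within the scatter, so the position responds to some changes but the new group cannot be ranked against aminomethyl. Nothing measured here explains the difference between the new group and carbamoyl or hydroxymethyl.

The compounds shown leave open which part of the new group matters, and whether a nitrile, a carboxylic acid or a longer chain on this aromatic carbon would give a similar number. They also leave open whether the same change would give a similar step on a different core.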